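Swapping Furan for Fluorophenyl on a Spiro Scaffold

The compounds below may be only part of what the source reports. "The series", "measured", "known", "first", "only" and "open" are said of these compounds alone.

Measured compounds:
compound 1 `CN1C[C@@H](c2ccc(F)cc2)[C@@]2(Cc3ccccc3C2=O)[C@@]12C(=O)Nc1ccccc12`, 21.2%
compound 2 `CN1C(=O)[C@@]2(c3ccccc31)N(C)C[C@@H](c1ccco1)[C@@]21Cc2ccccc2C1=O`, 33.1%

In a functional assay on the whole organism (strain Wister albino) for inhibition, with Rattus norvegicus as the target, read by paw edema, with stated times of 1 h and 2 h, at a dose of 50 mg/kg by the intraperitoneal route (on this read-out higher numbers stand for more inhibition at the one dose given (going by the name of the read-out) and lower numbers for less inhibition), compound 2 gives 33.1%, the higher of the two numbers; compound 1 gives 21.2%, which lies below it beyond the scatter. Compound 3 `CN1C(=O)[C@@]2(c3ccccc31)N(C)C[C@@H](c1ccc(F)cc1)[C@@]21Cc2ccccc2C1=O` differs from compound 2 by 4-fluorophenyl in place of furan-2-yl on a saturated ring carbon. Within the data shown here, no step on this scaffold is measured for this change, so the expectation rests only on the gap between compound 1 and compound 2. A modest downward step is expected from a number 8.1 percentage points lower from compound 2 to compound 3 (within the scatter). Compound 3 is therefore expected to give about 25%, with a range from 12% to 38%.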

Compound 3, a percentage reported as inhibition, in the whole organism at one dose (the size of the read-out at that dose, not a potency): 24.6%
Compound 3: the middle estimate sits 0.4 percentage points above what was measured; low and high end bracket the measured number.
By their numbers in this assay, from the lowest: compounds 1, 3 and 2 (each within the scatter of the next, the first and the last beyond it).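

In this assay, 4-fluorophenyl in place of furan-2-yl on the saturated ring carbon gives a number 8.5 percentage points lower from compound 2 to compound 3 (within the scatter), so this read-out does not separate the two aromatic rings at this position. Methyl in place of hydrogen on the amide-type nitrogen gives a number 3.4 percentage points higher from compound 1 to compound 3 (within the scatter), so that change is not separated either while 4-fluorophenyl is in place. Nothing available explains either step. Open remains whether an amine, a carboxylic acid or a longer chain on this carbon would move the number beyond the scatter, and whether furan-2-yl gives a similar number with hydrogen on the amide-type nitrogen.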